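The source may hold more compounds than are shown below. What is called first, only, known or untested is meant among the compounds shown, and "the series" means these compounds.

In an assay on isolated protein for displacement of a labelled ligand from metabotropic glutamate receptor 5 (Homo sapiens), with a stated time of 60 min, tested at 1 uM (on this read-out lower numbers stand for less inhibition and higher numbers for more inhibition at the one concentration tested (going by the name of the read-out)), compound 2 `Cc1ccc2ncc(S(=O)(=O)c3cc(F)cc(F)c3)c(N3CCC(C)CC3)c2c1` gives 72%. Compound 1 `Cc1ccc2ncc(S(=O)(=O)c3cc(Cl)cc(Cl)c3)c(N3CCC(C)CC3)c2c1` gives 75% in this assay, and the step of a number 3 percentage points lower from compound 1 to compound 2 (within the scatter) leaves the two within the scatter of each other, so compound 2 stands alongside compound 1 rather than apart from it. Compound 3 `Cc1ccc2ncc(S(=O)(=O)c3cccc(Cl)c3)c(N3CCC(C)CC3)c2c1` differs from compound 2 in one place: 3-chlorophenyl in place of 3,5-difluorophenyl on a sulfonyl sulfur. For the measured compounds named here, the one measured step that bears on this change, a number 3 percentage points lower from compound 1 to compound 2 (within the scatter), also exchanged one halogenated phenyl for another on the sulfonyl sulfur and did not move the read-out beyond the scatter. On that basis the step in this assay is expected to be a number 4 percentage points lower from compound 2 to compound 3 (within the scatter), that is, none beyond the scatter, since compound 1 and compound 2 show that the halogen pattern on this phenyl ring barely matters here. The estimate for compound 3 in this assay is therefore 68%, with a range from 50% to 85%.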

Compound 3, a percentage reported as inhibition, at one concentration (the size of the read-out at that concentration, not a potency): 91%
For compound 3 the middle estimate is 23 percentage points below the measured one; the whole stated range lies below it.
By their numbers in this assay, from the lowest: compounds 2 and 1 (each within the scatter of the next); then compound 3.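

In this assay, the substitution on the phenyl ring on a sulfonyl sulfur turns out to matter: the exchange of 3,5-difluorophenyl for 3-chlorophenyl brings a number 19 percentage points higher from compound 2 to compound 3 (beyond the scatter), and hydrogen in place of chloro on an aromatic carbon brings a number 16 percentage points higher from compound 1 to compound 3 (beyond the scatter). The exchange between the two dihalogenated rings had stayed within the scatter, whereas the ring with a single chlorine stands apart from both, so the earlier pair gave no sign of this sensitivity. Nothing measured here accounts for the difference.

The compounds shown leave open how a plain phenyl or a methoxyphenyl group would read on this sulfonyl sulfur. They also leave open whether the step carries over when a morpholine replaces the saturated amine on the shared core.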